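Aryl ester variation on the shared flavone core

This account rests on a few compounds, and the source may have more. Where it says the series, first, only, none or still open, it means among the compounds named here.

Measured so far:
Compound 1, `COC(=O)c1cc(Cl)ccc1OC(=O)COc1cc(O)c2c(=O)cc(-c3ccccc3)oc2c1`: 3740 nM
Compound 2, `COC(=O)c1cccc(OC)c1OC(=O)COc1cc(O)c2c(=O)cc(-c3ccccc3)oc2c1`: 36800 nM
Compound 3, `COC(=O)c1cc(O)ccc1OC(=O)COc1cc(O)c2c(=O)cc(-c3ccccc3)oc2c1`: 29500 nM

In a functional assay on cells (T-cell, Mus musculus, strain BALB/c) for inhibition, read by MTT assay, with a stated time of 72 h (a higher number here means a weaker inhibitor, a lower number a stronger inhibitor), compound 3 gives the second highest of the three numbers; compound 2 lies within the scatter of it, and compound 1 sits well below both. Among the measured compounds shown here, the one measured step that touches compound 3 is a 7.9-fold higher number from compound 1 to compound 3 (0.90 log units; beyond the scatter).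

Compound 4, `COC(=O)c1cccc(C)c1OC(=O)COc1cc(O)c2c(=O)cc(-c3ccccc3)oc2c1`, differs from compound 3 by a group of 11 heavy atoms (9 carbon, 2 oxygen; one six-membered aromatic ring of carbon only) in place of a group of 11 heavy atoms (8 carbon, 3 oxygen; one six-membered aromatic ring of carbon only), on an oxygen next to a carbonyl group. For the measured compounds named here, no measured step mirrors this exactly; the step from compound 1 to compound 3 only shows that this part of the structure moves the number. Compound 4 is therefore expected to land between compound 1 and compound 3, with a 3.3-fold lower number from compound 3 to compound 4 (0.52 log units; beyond the scatter) as the expected step. The estimate for compound 4 is 9000 nM, range 2500 nM to 35000 nM.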

Compound 4, half-maximal inhibitory concentration: 39100 nM
For compound 4 the middle estimate is 4.3-fold (0.64 log units) below the measured one; the measured number lies above the stated range.
By their numbers in this assay, from the lowest: compound 1; then compounds 3, 2 and 4 (each within the scatter of the next).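

Methyl in place of methoxy on an aromatic carbon leaves the number unresolved in this assay (a 1.1-fold higher number from compound 2 to compound 4 (0.03 log units; within the scatter)), and the group of compound 4 is likewise not separated from that of compound 3 (a 1.3-fold higher number from compound 3 to compound 4 (0.12 log units; within the scatter)). Compound 1 alone stands apart among these four (a 10-fold higher number from compound 1 to compound 4 (1.02 log units; beyond the scatter)), so the methyl, methoxy and hydroxy compounds form one level and the chloro compound goes against it. No available data bear on why this is so.

Open, from the compounds shown here alone, is whether bromo, fluoro or an amine on this aromatic ring would match compound 1 or join the other three.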